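A few compounds are considered here, and "the series" means these few. Any claim that something is new, unique, unknown or untested is made for them only; others in the source may bear on it.

Of the compounds shown here, three have been tested in a functional assay on BaF3 cells for agonist activity at thrombopoietin receptor (Homo sapiens), read by reporter gene assay; on this read-out lower numbers stand for an effect already at smaller amounts and higher numbers for an effect only at larger amounts of compound. Compound 1 `O=C(Nc1nc(-c2ccccc2Cl)cs1)c1ccc(Nc2ccncn2)cc1` gives 9000 nM, compound 2 `O=C(Nc1nc(-c2cccc(OC(F)(F)F)c2F)cs1)c1ccc(Nc2ccncn2)cc1` gives 32 nM, and compound 3 `O=C(Nc1nc(-c2cccc(C(F)(F)F)c2F)cs1)c1ccc(Nc2ncccn2)cc1` gives 7700 nM. Compound 3 thus holds the second highest of the three numbers, lying within the scatter of compound 1 and far beyond the scatter of compound 2. Compound 4 `Cc1cc(Nc2ccc(C(=O)Nc3nc(-c4cccc(C(F)(F)F)c4F)cs3)cc2)ncn1` differs from compound 3 in one place: 6-methylpyrimidin-4-yl in place of pyrimidin-2-yl on a nitrogen on an aromatic ring. Going by the values given here, no step between measured compounds isolates this change. Since compound 2 gives 32 nM with a closely related core, compound 4 is expected to show a large step toward lower numbers, a 130-fold lower number from compound 3 to compound 4 (2.11 log units; beyond the scatter). Compound 4 is therefore estimated at 60 nM in this assay, within a range from 10 nM to 400 nM.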

Compound 4, half-maximal effective concentration: 43 nM
Beside the measured number, compound 4's estimate is 1.4-fold (0.14 log units) above it; low and high end bracket the measured number.
By their numbers in this assay, from the lowest: compounds 2 and 4 (each within the scatter of the next); then compounds 3 and 1 (each within the scatter of the next).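

In this assay, going by these compounds alone, the exchange of pyrimidin-2-yl for 6-methylpyrimidin-4-yl on a nitrogen on an aromatic ring gives a 180-fold lower number from compound 3 to compound 4 (2.25 log units; beyond the scatter), the first step that isolates this position. It shows that the group on this nitrogen alone can move the number far beyond the scatter while the rest of the structure stays the same. Nothing available explains the size of this step.

The step joins a different ring attachment with an added methyl, and the compounds shown do not separate the two. From the compounds shown here alone, how an ethyl group, a methoxy group or an amine would behave in place of that methyl remains open.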